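A Cyclopentyl Amine in Place of an Aryl Amine

The source may report more compounds than this note shows. Statements on the series, on what has been measured and on what is new or still open speak of the compounds shown alone.

Compound 1 `Cc1ccc(NC2=CC(=O)c3nc4n(c3C2=O)[C@H]2OC[C@@H](O)[C@H]2OC4)cc1C` and compound 2 `CCCc1ccc(NC2=CC(=O)c3c(nc4n3[C@H]3OC[C@@H](O)[C@H]3OC4)C2=O)cc1` share a core and differ only in the group carried on the amine nitrogen. In a functional assay on HeLa cells (Homo sapiens) for inhibition, read by sulforhodamine B assay (a higher number here means a weaker inhibitor, a lower number a stronger inhibitor), compound 1 gives 2690 nM, while compound 2 gives 6030 nM. Compound 2 therefore stands at the higher of the two numbers, with compound 1 as its nearest neighbour at a lower number; that gap is beyond the scatter, so compound 2 is the weaker inhibitor of the measured pair.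

Compound 3 `O=C1C(NC2CCCC2)=CC(=O)c2c1nc1n2[C@H]2OC[C@@H](O)[C@H]2OC1` has not yet been measured. Relative to compound 2 it carries cyclopentyl in place of 4-propylphenyl on an amine nitrogen. Going by the values given here, no pair of measured compounds shows a change of this kind, so no step size can be read off from the data for it. Without such a reference, the expectation is a moderate step towards a higher number, somewhat beyond the scatter but held with little confidence about its direction, estimated as a 1.5-fold higher number from compound 2 to compound 3 (0.17 log units; within the scatter). In this assay compound 3 is accordingly expected to give 9000 nM, within a range from 3000 nM to 30000 nM.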

Compound 3, half-maximal inhibitory concentration: > 16000 nM
Compound 3: no number, only a limit (the forecaster's own chance of this, stated with the estimate: 10%); middle value at least 1.7-fold (0.24 log units) from the limit.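

In this assay compound 3 gives > 16000 nM, which is a limit of the assay and not a number. Exchanging 4-propylphenyl for cyclopentyl on this amine nitrogen gives an at least 2.6-fold higher number from compound 2 to compound 3 (0.42 log units; beyond the scatter), the first step shown at this position, and it shows that replacing the six-membered aromatic ring with a five-membered non-aromatic ring moves compound 3 towards weaker inhibition, with the full size of that step left unfixed: the limit of > 16000 nM in this assay, at which 1 of the 3 values shown sits. Until this result, the compounds shown carried only an aromatic ring on this nitrogen, and both gave a measured number, with compound 1 at 2690 nM and compound 2 at 6030 nM.

The change from compound 2 to compound 3 alters the ring and the number of heavy atoms together, and the compounds shown cannot separate the two. As far as these compounds go, whether a cyclohexyl group, which keeps a non-aromatic ring but is larger, or an unsubstituted phenyl group, which keeps the aromatic ring without the propyl chain, would stay closer to compound 2 remains open.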